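The source may report more compounds than this note shows. Statements on the series, on what has been measured and on what is new or still open speak of the compounds shown alone.

- compound 1 `Cc1cc(NC(=O)Nc2ccc(C(C)(C)C)cc2)c2ccccc2n1`: 6200 nM
- compound 2 `CC(=O)c1ccc(NC(=O)Nc2cc(C)nc3ccccc23)cc1`: 3800 nM
- compound 3 `Cc1cc(NC(=O)Nc2ccccc2C(C)(C)C)c2ccccc2n1`: 100 nM

In a physicochemical assay for solubility, at pH 7.4 (on this read-out higher numbers stand for higher solubility and lower numbers for lower solubility), compound 2 gives 3800 nM, which sits within the scatter of compound 1 at 6200 nM. Together they form the upper pair of the three numbers. The remaining number belongs to compound 3, which gives 100 nM.

The next compound to be read is compound 4 `COC(=O)c1ccc(NC(=O)Nc2cc(C)nc3ccccc23)cc1`. Its difference from compound 2 is methoxy in place of methyl on a carbonyl carbon, or acetyl to methoxycarbonyl.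

Among the measured compounds shown here, no measured step makes this exact change. The nearest evidence is a 1.6-fold lower number from compound 1 to compound 2 (0.21 log units; within the scatter), with acetyl in place of tert-butyl on an aromatic carbon, and that step stays within the scatter. It is a single step and a different exchange, so it offers only weak support. On that basis, no change beyond the scatter is expected in this assay, and no direction is favoured with any confidence.

The expected step is a 1.3-fold lower number from compound 2 to compound 4 (0.10 log units; within the scatter). For compound 4 the estimated value is 3000 nM, with an expected range of 1000 nM to 8000 nM.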

Compound 4, solubility: 1200 nM
The estimate for compound 4 lay 2.5-fold (0.40 log units) above the measured number; measured number inside the range.
By their numbers in this assay, from the lowest: compound 3; then compound 4; then compounds 2 and 1 (each within the scatter of the next).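

In this assay, methoxy in place of methyl on a carbonyl carbon gives a 3.2-fold lower number from compound 2 to compound 4 (0.50 log units; beyond the scatter) and so is the first exchange shown at this carbonyl to go beyond the scatter. Acetyl had stayed within the scatter of tert-butyl in a 1.6-fold lower number from compound 1 to compound 2 (0.21 log units; within the scatter) but methoxycarbonyl does not, as seen in a 5.2-fold lower number from compound 1 to compound 4 (0.71 log units; beyond the scatter) and so acetyl and methoxycarbonyl are not interchangeable on this aromatic carbon, even though both carry a carbonyl. No measurement at hand accounts for this difference.

Still open, going by these compounds, is whether the lower number belongs to methoxy specifically or would recur with other groups on the same carbonyl carbon, such as ethoxy, an amine or the hydroxyl of a carboxylic acid. A single pair also leaves open whether this exchange gives a step of similar size elsewhere in the series.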